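The compounds below may be only part of what the source reports. "The series", "measured", "known", "first", "only" and "open" are said of these compounds alone.

In a functional assay on K562 cells (Homo sapiens) for antiproliferative activity, read by CCK-8 assay, with a stated time of 72 h (a lower number here means a stronger inhibitor of growth, a higher number a weaker inhibitor of growth), two compounds of this series have been measured so far. Compound 1 `CC[C@@H]1C(=O)N(C)c2cnc(-n3ccc4cc(C(N)=O)ccc43)nc2N1C1CCCC1` gives 1850 nM, and compound 2 `CCC1C(=O)N(C)c2cnc(-n3ccc4cc(C(=O)NC(C)C)ccc43)nc2N1c1ccn(C)n1` gives 8910 nM. Compound 1 therefore holds the lower of the two numbers, and the gap between them lies beyond the usual scatter. The next compound, compound 3 `CC[C@@H]1C(=O)N(C)c2cnc(-n3ccc4cc(C(=O)NC(C)C)ccc43)nc2N1C1CCCC1`, keeps the core of compound 1 and changes only its carbamoyl group, with isopropyl in place of hydrogen on an amide-type nitrogen. Going by the values given here, compound 2 already carries isopropylcarbamoyl, but it differs from compound 1 elsewhere as well, so no measured pair isolates this change. Among the compounds with values here, compound 2 at 8910 nM shows only that a compound with this group can still give a measurable number, and it offers no clean guide to the size of the step. A modest move toward a lower number is therefore expected, though a move the other way cannot be excluded, and the estimated change is a 1.9-fold lower number from compound 1 to compound 3 (0.27 log units; within the scatter). For compound 3 the expected value is 1000 nM, with an estimated range from 180 nM to 5000 nM.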

Compound 3, concentration for 50% growth inhibition: 786 nM
The estimate for compound 3 lay 1.3-fold (0.10 log units) above the measured number, and the stated range covers the measured number.
By their numbers in this assay, from the lowest: compound 3; then compound 1; then compound 2.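

In this assay, going by these compounds alone, isopropyl in place of the amide hydrogen gives a 2.4-fold lower number from compound 1 to compound 3 (0.37 log units; beyond the scatter), and this is the first pair of compounds that isolates the change. The amide-type nitrogen, whose other neighbour is the carbonyl carbon, therefore accepts the isopropyl group on the core of compound 1 without any loss of growth inhibition, and the step, though modest, lies beyond the usual scatter, which the earlier values could not establish. The data offer no measured property that would account for this step, so the result stands as an observation only.

The compounds shown leave open whether the trend continues with other groups on this nitrogen, such as methyl, a longer alkyl chain, or a chain ending in an amine or a carboxylic acid, since a single substituent gives one point and no trend. They also leave open whether the step carries over to other cores: compound 2 bears the same isopropylcarbamoyl group, but it has no partner among these compounds that differs from it in this one place alone.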